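Extending the Hydroxylated Ester Chain: Compound 3 to Compound 4

This account rests on a few compounds, and the source may have more. Where it says the series, first, only, none or still open, it means among the compounds named here.

Compound 1 `CCC(C)(O)CC(=O)O[C@H](CC=C(C)C)C1=CC(=O)c2c(O)ccc(O)c2C1=O`: 25200 nM
Compound 2 `COC(C)CO[C@H](CC=C(C)C)C1=CC(=O)c2c(O)ccc(O)c2C1=O`: 53400 nM
Compound 3 `CC(C)=CC[C@@H](OC(=O)C1CCCO1)C1=CC(=O)c2c(O)ccc(O)c2C1=O`: 17000 nM

Three measured compounds share one core and differ only in the group on the oxygen on the saturated carbon of the side chain. In a functional assay on HeLa cells (Homo sapiens) for cytotoxicity, read by MTT assay (on this read-out lower numbers stand for stronger inhibition and higher numbers for weaker inhibition), compound 3 gives the lowest of the three numbers; its nearest neighbour is compound 1, with a 1.5-fold lower number from compound 1 to compound 3 (0.17 log units; within the scatter) staying inside the scatter, while compound 2 lies furthest away, with a 3.1-fold lower number from compound 2 to compound 3 (0.50 log units; beyond the scatter). The unmeasured compound 4 `CCCCC(C)(O)CC(=O)O[C@H](CC=C(C)C)C1=CC(=O)c2c(O)ccc(O)c2C1=O` differs from compound 3 by 2-hydroxy-2-methylhexyl in place of oxolan-2-yl on a carbonyl carbon.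

The step that bears most directly on this change is the one between the open hydroxylated chain of compound 1 and the ring of compound 3, a 1.5-fold lower number from compound 1 to compound 3 (0.17 log units; within the scatter), which did not leave the scatter. The other two steps, a 2.1-fold higher number from compound 1 to compound 2 (0.33 log units; beyond the scatter) and a 3.1-fold lower number from compound 2 to compound 3 (0.50 log units; beyond the scatter), concern the ether of compound 2 and speak less to the present change. Compound 4 carries an open chain of the same kind as compound 1, only longer, so the number for compound 4 is expected to move back toward that of compound 1, which means a 1.3-fold higher number from compound 3 to compound 4 (0.11 log units; within the scatter) is expected, a step that need not exceed the scatter. Compound 4 is therefore estimated at 22000 nM, with a range from 9000 nM to 55000 nM.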

Compound 4, half-maximal inhibitory concentration: 60600 nM
Compound 4: middle estimate off by 2.8-fold (0.44 log units), on the low side; the whole stated range lies below it.
By their numbers in this assay, from the lowest: compounds 3 and 1 (each within the scatter of the next); then compounds 2 and 4 (each within the scatter of the next).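

In this assay, the length of the open chain on the carbonyl carbon matters, as ethyl in place of hydrogen on a saturated chain carbon gives a 2.4-fold higher number from compound 1 to compound 4 (0.38 log units; beyond the scatter) and so separates two chains of the same kind by more than the scatter. The exchange of oxolan-2-yl for an open hydroxylated chain, which stayed within the scatter with the shorter chain of compound 1, now gives a 3.6-fold higher number from compound 3 to compound 4 (0.55 log units; beyond the scatter) with 2-hydroxy-2-methylhexyl as the entering group, so the outcome of that exchange depends on the chain that enters. The gap that had set the group of compound 1 apart from 2-methoxypropyl is also gone, since a 1.1-fold higher number from compound 2 to compound 4 (0.05 log units; within the scatter) places (2-hydroxy-2-methylhexyl)carbonyl and 2-methoxypropyl within the scatter of each other.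

Nothing among the data shown accounts for this effect of the added ethyl. From the compounds shown here alone, it stays open whether a 2-hydroxy-2-methylpentyl chain would fall with compound 1 or with compound 4, and whether an amine in place of the hydroxyl on the chain would change the number at all.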